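A few compounds are considered here, and "the series" means these few. Any claim that something is new, unique, unknown or untested is made for them only; others in the source may bear on it.

Compound 1 `Cc1ccccc1-c1nn(C(C)C)cc1CNCCN1CCN(C)CC1` — > 20000 nM
Compound 2 `Cc1ccccc1-c1nn(-c2ccc(F)cc2F)cc1CNCCCCO` — > 20000 nM
Compound 3 `CSc1ccc(-n2cc(CNCCN3CCN(C)CC3)c(-c3ccccc3C)n2)cc1` — 17000 nM

In an ADME assay on Huh-7 cells (Homo sapiens) for cytotoxicity (on this read-out lower numbers stand for higher toxicity in this test and higher numbers for lower toxicity in this test), compound 1 gives > 20000 nM, which is a limit of the assay rather than a number. Compound 2 gives > 20000 nM, again a limit and not a number. Compound 3, by contrast, gives a measured number of 17000 nM. The only step measured between two of these compounds is an at least 1.1-fold lower number from compound 1 to compound 3 (0.07 log units; that floor lies within the scatter), a change that does not leave the usual scatter. Within the data shown here, compound 2 therefore stands at the limit of > 20000 nM in this assay, at which 2 of the 3 values shown sit, and no measured step reaches from it to any other compound.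

Compound 4 `Cc1ccccc1-c1nn(-c2ccc(F)cc2F)cc1CNCc1ccncc1` is the next compound to be tested in this assay. It differs from compound 2 in one place: pyridin-4-yl in place of 3-hydroxypropyl on a saturated chain carbon bound to an amine nitrogen. Among the measured compounds shown here, no measured step concerns this position; the single step recorded, from compound 1 to compound 3, touches a different part of the molecule and lies within the scatter, so it offers no direction for this change. Compound 4 is thus expected to show a step of a number no higher from compound 2 to compound 4 (the limit leaves the size open) from compound 2, that is, no change beyond the scatter. Compound 4 is estimated at 20000 nM, with a range from 8000 nM to 50000 nM.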

Compound 4, half-maximal cytotoxic concentration: > 20000 nM
Compound 4: no number, only a limit; the forecaster's own chance of this, stated with the estimate: 60%; the middle value lies on the limit itself.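

In this assay compound 4 gives > 20000 nM, a limit of the assay and not a number. Compound 2 also stands at a limit, and the step from it to compound 4 cannot be read. The compounds shown leave open whether pyridin-4-yl in place of 3-hydroxypropyl changes the read-out at all.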